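Exchanging One Group on Compound 2

The compounds below may be only part of what the source reports. "The series", "measured", "known", "first", "only" and "open" are said of these compounds alone.

In a physicochemical assay for lipophilicity, read by HPLC, measured as chromatographic lipophilicity (on this read-out lower numbers stand for lower lipophilicity and higher numbers for higher lipophilicity), compound 1 `CCC/N=C1\S/C(=C\c2ccc(C(=O)NCCO)cc2)C(=O)N1c1ccccc1C` gives 2.3, while compound 2 `CCC/N=C1\S/C(=C\c2ccc(C(=O)NCC(=O)N(C)C)cc2)C(=O)N1c1ccccc1O` gives 1.9. Compound 2 therefore holds the lower of the two numbers, and the gap between them lies beyond the usual scatter. The next molecule, compound 3 `CCC/N=C1\S/C(=C\c2ccc(C(=O)OCCCO)cc2)C(=O)N1c1ccccc1O`, carries 3-hydroxypropoxy in place of ((dimethylcarbamoyl)methyl)amino on a carbonyl carbon. Cut one bond further out, the same difference reads ((dimethylcarbamoyl)methyl)carbamoyl to (3-hydroxypropoxy)carbonyl. Among the measured compounds shown here, the two measured compounds differ in more than one place, so no measured step shows what this exchange does alone, and the expectation is a judgement from the structures. A rise beyond the scatter is expected, with the estimated change being a number 0.80 log units higher from compound 2 to compound 3 (beyond the scatter). The estimate for compound 3 is 2.7, with an expected range of 2.2 to 3.2.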

Compound 3, distribution coefficient: 2.3
Beside the measured number, compound 3's estimate is 0.40 log units above it, and the stated range covers the measured number.
By their numbers in this assay, from the lowest: compound 2; then compounds 1 and 3 (each within the scatter of the next).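

In this assay, putting 3-hydroxypropoxy in place of ((dimethylcarbamoyl)methyl)amino on a carbonyl carbon gives a number 0.40 log units higher from compound 2 to compound 3 (beyond the scatter). Among the compounds shown here, this is the first comparison of two compounds that differ in only one place, so the change can be tied to this single exchange, and the number goes up even though the entering group is the smaller one, with 5 heavy atoms against 7, no nitrogen, and 2 hydrogen-bond acceptors against 1. No measurement available here explains the rise.

The exchange alters both the atom attached to the carbonyl carbon and the chain beyond it, so this one step cannot show how much each part contributes. A 3-hydroxypropylamino group at the same place would separate the two, while a carboxylic acid there would show how the number responds to a much shorter group.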